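The source may hold more compounds than are shown below. What is called first, only, known or untested is meant among the compounds shown, and "the series" means these compounds.

Measured so far in a functional assay on CHO-K1 cells for antagonist activity at transient receptor potential cation channel subfamily V member 1 (Homo sapiens), read by FLIPR; on this read-out higher numbers stand for weaker inhibition and lower numbers for stronger inhibition:
- compound 1 `CC(C(=O)NCc1ccc(C(F)(F)F)nc1NCC1CCN(C(=O)OC(C)(C)C)CC1)c1ccc(NS(C)(=O)=O)c(F)c1` gives 19.3 nM
- compound 2 `CC(C(=O)NCc1ccc(C(F)(F)F)nc1Nc1ccccc1)c1ccc(NS(C)(=O)=O)c(F)c1` gives 59.6 nM

Compound 2 stands at the higher of the two numbers; compound 1 sits at a clearly lower number, and the gap between them lies beyond the scatter. Within the data shown here, the two differ in more than one place, so no single step is counted between them.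

Compound 3 `CC(C(=O)NCc1ccc(C(F)(F)F)nc1NCc1ccccc1)c1ccc(NS(C)(=O)=O)c(F)c1` has not yet been measured in this assay. It differs from compound 2 by benzyl in place of phenyl on a nitrogen on an aromatic ring. Among the measured compounds shown here, no measured pair carries exactly this change, so there is no counted step to lean on; the only anchor is that compound 1, with its value 19.3 nM, shows the lower end of the range seen so far.

On that basis a modest move toward lower numbers is expected, though one that may stay within the scatter. For compound 3 in this assay the estimate is 30 nM, with a range of 10 nM to 90 nM. The expected step is a 2.0-fold lower number from compound 2 to compound 3 (0.30 log units; within the scatter).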

Compound 3, inhibition constant: 15.8 nM
For compound 3 the middle estimate is 1.9-fold (0.28 log units) above the measured one; the range from low to high includes it.
By their numbers in this assay, from the lowest: compounds 3 and 1 (each within the scatter of the next); then compound 2.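

In this assay, among these compounds, benzyl in place of phenyl on a nitrogen on an aromatic ring gives a 3.8-fold lower number from compound 2 to compound 3 (0.58 log units; beyond the scatter), and this is the only single-place step counted so far. The earlier compounds shown here could not show this, as they differ in more than one place; the pair now shows that the read-out responds to the change from anilino to benzylamino with the rest of the structure held constant. No measured evidence bears on the reason for this step.

Still open, as far as these compounds go, is whether phenethyl, a longer chain at this nitrogen, or a benzyl group carrying an amine or a carboxylic acid, would stay near compound 3 at 15.8 nM. Also open, from the compounds shown here alone, is whether the same change gives a similar step on any other core.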